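Swapping the amide nitrogen group of compound 1

The source may hold more compounds than are shown below. What is called first, only, known or untested is meant among the compounds shown, and "the series" means these compounds.

- compound 1 `COC(=O)CCNC(=O)[C@H]1CC=C(CCC=C(C)C)C[C@@H]1c1ccccc1` gives 96800 nM 
- compound 2 `CC(C)=CCCC1=CC[C@H](C(=O)NO)[C@@H](c2ccccc2)C1` gives 72300 nM 

Measured in a functional assay on MCF7 cells (Homo sapiens) for antiproliferative activity (a higher number here means a weaker inhibitor, a lower number a stronger inhibitor), these two compounds lie within the scatter of each other, so compound 1 holds no clear place above or below compound 2. Compound 3 `CONC(=O)[C@H]1CC=C(CCC=C(C)C)C[C@@H]1c1ccccc1` alters compound 1 at one place (methoxy in place of 2-(methoxycarbonyl)ethyl on an amide-type nitrogen): methoxy in place of 2-(methoxycarbonyl)ethyl on an amide-type nitrogen. Among the compounds with values here, the only measured step at that nitrogen puts hydroxy in place of the same group (a 1.3-fold lower number from compound 1 to compound 2 (0.13 log units; within the scatter)) and stays within the scatter. No step beyond the scatter is therefore expected in this assay for the new change, and the estimated step is small (a 1.2-fold lower number from compound 1 to compound 3 (0.08 log units; within the scatter)). For compound 3 the expected value is 80000 nM with an estimated range from 40000 nM to 160000 nM in this assay.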

Compound 3, half-maximal inhibitory concentration: 45200 nM
For compound 3 the middle estimate is 1.8-fold (0.25 log units) above the measured one, and the stated range covers the measured number.
By their numbers in this assay, from the lowest: compounds 3, 2 and 1 (each within the scatter of the next, the first and the last beyond it).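

In this assay, the amide-type nitrogen now shows its first step beyond the scatter: methoxy in place of 2-(methoxycarbonyl)ethyl gives a 2.1-fold lower number from compound 1 to compound 3 (0.33 log units; beyond the scatter), a modest change, while compound 2 stayed within the scatter of compound 1. Methyl in place of hydrogen on the oxygen gives a 1.6-fold lower number from compound 2 to compound 3 (0.20 log units; within the scatter), so hydroxy and methoxy are not separated here. No evidence is available that bears on this result. The compounds shown leave open whether a longer chain on that oxygen, or an amine or a carboxylic acid at the end of the chain on the nitrogen, would shift the number further.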